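The compounds below may be only part of what the source reports. "The series", "measured", "known", "first", "only" and "open" are said of these compounds alone.

Working notes on a short amide series measured in a functional assay on SiHa cells (Homo sapiens) for cytotoxicity, read by MTT assay, with a stated time of 48 h; a lower number here means a stronger inhibitor, a higher number a weaker inhibitor. Compound 1 `CCCCCCCCNC(=O)[C@@H](NC(=O)/C=C/c1ccccc1)[C@@H](C)O` gives 41400 nM in this assay. Compound 2 `CCCCCCCCCCCCNC(=O)[C@@H](NC(=O)/C=C/c1ccccc1)[C@@H](C)O` carries the change butyl in place of hydrogen on a saturated chain carbon, eight bonds along the chain from an amide-type nitrogen relative to compound 1. In this assay compound 2 reaches only the limit > 200000 nM. From the compounds shown here alone, the measured step is an at least 4.8-fold higher number from compound 1 to compound 2 (0.68 log units; beyond the scatter); it rests on (the limit of > 200000 nM in this assay, at which 2 of the 3 values shown sit), so its true size stays open. Compound 3 `CCCCCCCCCCCCCCNC(=O)[C@@H](NC(=O)c1ccccc1)[C@@H](C)O` has a different core; the difference between the core of compound 3 and that of compound 1 is not broken down here. In this assay compound 3 also sits at the limit > 200000 nM. Compound 4 `CCCCCCCCCCCCCCCCCCNC(=O)[C@@H](NC(=O)c1ccccc1)[C@@H](C)O`, not yet measured in this assay, differs from compound 3 by butyl in place of hydrogen on a saturated chain carbon, ten or more bonds along the chain from an amide-type nitrogen. This is the same kind of change as from compound 1 to compound 2, though the place along the chain differs, as the two descriptions of the differences show. Compound 3 already stands at the limit > 200000 nM. The same kind of change earlier gave an at least 4.8-fold higher number from compound 1 to compound 2 (0.68 log units; beyond the scatter), and compound 4 is therefore expected to stay at the limit as well, an expected step that the limit leaves unreadable from compound 3 to compound 4. The estimate for compound 4 in this assay is 300000 nM, between 150000 nM and 1000000 nM.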

Compound 4, half-maximal inhibitory concentration: 38200 nM
For compound 4 the middle estimate is 7.9-fold (0.90 log units) above the measured one, and the stated range ends above it.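

In this assay, butyl in place of hydrogen on a saturated chain carbon, ten or more bonds along the chain from an amide-type nitrogen, gives an at least 5.2-fold lower number from compound 3 to compound 4 (0.71 log units; beyond the scatter), so the direction of this change does not carry over from the core of compound 1 to the core of compound 3: the same change on two cores in this assay, an at least 4.8-fold higher number (0.68 log units; beyond the scatter) from compound 1 to compound 2 and an at least 5.2-fold lower number (0.71 log units; beyond the scatter) from compound 3 to compound 4, at least 25-fold (1.40 log units) apart, beyond the scatter of two such steps

Both steps start or end at a limit, so the opposite directions can be read but their true sizes stay open: the limit of > 200000 nM in this assay, at which 2 of the 4 values shown sit.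

The result does not show whether the reversal goes with the core or with the place along the chain, since the two steps differ in both, and two steps set no rule for the series.

Open remains whether the same butyl change on the chain of compound 2 would also bring the number down on the core of compound 1. Also open, from the compounds shown here alone, is how a longer chain on the core of compound 3, or an amine or a carboxylic acid on the chain, would read in this assay.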